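This account rests on a few compounds, and the source may have more. Where it says the series, first, only, none or still open, it means among the compounds named here.

Working notes, series of the shared core measured in an assay (Rattus norvegicus) for inhibition of Fatty-acid amide hydrolase 1 (Homo sapiens); on this read-out lower numbers stand for stronger inhibition and higher numbers for weaker inhibition. Compound 1 `O=C(CCCCCCc1ccccc1)c1ncc(-c2cccc(C(=O)C(F)(F)F)c2)o1` gives 16 nM. Compound 2 `N#Cc1cccc(-c2cnc(C(=O)CCCCCCc3ccccc3)o2)c1` gives 15 nM. Compound 3 `O=C(CCCCCCc1ccccc1)c1ncc(-c2cncnc2)o1` gives 22 nM. Compound 2 sits at the low end of these three numbers, with compound 1 nearest and compound 3 furthest, but both gaps lie within the scatter, so no ranking among them is supported. The two steps recorded, a 1.1-fold lower number from compound 1 to compound 2 (0.03 log units; within the scatter) and a 1.5-fold higher number from compound 2 to compound 3 (0.17 log units; within the scatter), both left this assay essentially unchanged.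

Compound 4 `O=C(CCCCCCc1ccccc1)c1ncc(-c2nnn[nH]2)o1` differs from compound 2 in that (1H-tetrazol-5-yl in place of 3-cyanophenyl on an aromatic carbon). The step bearing most on this is a 1.5-fold higher number from compound 2 to compound 3 (0.17 log units; within the scatter), where 3-cyanophenyl gave way to pyrimidin-5-yl with no movement beyond the scatter. Among the measured compounds shown here, a change to a five-membered aromatic ring carrying a hydrogen-bond donor has no precedent, so the expectation is a modest upward drift at most, a 2.7-fold higher number from compound 2 to compound 4 (0.43 log units; beyond the scatter), with wide uncertainty. Compound 4 is therefore estimated at 40 nM, in the range 12 nM to 130 nM.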

Compound 4, inhibition constant: 63 nM
Compound 4: middle estimate off by 1.6-fold (0.20 log units), on the low side; the measured number falls inside the stated range.
By their numbers in this assay, from the lowest: compounds 2, 1 and 3 (each within the scatter of the next); then compound 4.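

At this position, on the aromatic carbon next to the ring oxygen, this assay now shows a change beyond the scatter: a 4.2-fold higher number from compound 2 to compound 4 (0.62 log units; beyond the scatter) and a 2.9-fold higher number from compound 3 to compound 4 (0.46 log units; beyond the scatter), both modest. The earlier swap of 3-cyanophenyl for pyrimidin-5-yl did not leave the scatter, so this position does not accept every aromatic group equally, although 1H-tetrazol-5-yl still costs only a modest step. Nothing measured here explains the rise.

The step from compound 2 to compound 4 changes ring size, hetero atoms and hydrogen-bond donors together, so the compounds shown cannot assign the rise to any one of these. On these data alone, how an unsubstituted phenyl or a carboxylic acid would stand on this carbon also remains open.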